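Swapping the amine ring on a coumarin-like core

A few compounds are considered here, and "the series" means these few. Any claim that something is new, unique, unknown or untested is made for them only; others in the source may bear on it.

Measured compounds:
- Compound 1 `CCN1CCN(c2c(C(C)=O)c(=O)oc3cc(Nc4ncc(F)c(-c5ccc(F)cc5OC)n4)ccc23)CC1`: 550 nM
- Compound 2 `CCN1CCN(c2c(C(C)=O)c(=O)oc3cc(Nc4nccc(-c5ccc(F)cc5OC)n4)ccc23)CC1`: 740 nM
- Compound 3 `COc1ccccc1-c1ccnc(Nc2ccc3c(C)c(C(C)=O)c(=O)oc3c2)n1`: 10200 nM

All three were tested in a functional assay on MV4-11 cells (Homo sapiens) for inhibition, read by luminescence and CellTiter-Glo, with a stated time of 72 h; on this read-out higher numbers stand for weaker inhibition and lower numbers for stronger inhibition. Compound 2 stands second highest of the three numbers. Going by the values given here, its nearest neighbour is compound 1, and the only single-change step recorded runs between them: a 1.3-fold higher number from compound 1 to compound 2 (0.13 log units; within the scatter), which is within the scatter. Compound 3 differs from compound 2 in more than one place, so its much higher number cannot be tied to any single change; it only shows that the numbers in this set span a wide range.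

Compound 4 `COc1cc(F)ccc1-c1ccnc(Nc2ccc3c(N4CCCCC4)c(C(C)=O)c(=O)oc3c2)n1` is not yet measured. It differs from compound 2 in one place: piperidin-1-yl in place of 4-ethylpiperazin-1-yl on an aromatic carbon. Among the compounds with values here, no measured step touches that position; the one recorded step concerns a fluoro elsewhere and was small. With nothing to anchor the change, the expectation is a step of modest size, if any, from compound 2 to compound 4, and the direction is uncertain. The estimate for compound 4 is 1000 nM, within a range of 350 nM to 3000 nM, corresponding to an expected step of a 1.4-fold higher number from compound 2 to compound 4 (0.13 log units; within the scatter).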

Compound 4, half-maximal inhibitory concentration: 730 nM
Estimate against measurement, compound 4: 1.4-fold (0.14 log units) above; measured number inside the range.
By their numbers in this assay, from the lowest: compounds 1, 4 and 2 (each within the scatter of the next); then compound 3.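

In this assay, replacing 4-ethylpiperazin-1-yl with piperidin-1-yl gives a 1.0-fold lower number from compound 2 to compound 4 (0.01 log units; within the scatter), so the two numbers cannot be told apart. Going by these compounds alone, this is the first reading at this position, the aromatic carbon opposite the ring oxygen and ortho to an acetyl group, and it shows that the ethyl group and the second ring nitrogen of 4-ethylpiperazin-1-yl can be removed without a step beyond the scatter in this pair, where the entering ring has one nitrogen and one hydrogen-bond acceptor in place of two of each. No measurement shown here explains why the two numbers lie so close together.

This single pair cannot show how far the position accepts other groups: a morpholine ring, an open-chain dimethylamino group or a carboxylic acid at the same carbon could each read very differently, and only such compounds could show whether a six-membered ring matters there at all. It also leaves open whether the same swap would read alike on compound 1, which carries one more fluoro than compound 2.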